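Swapping the Carboxy Group of Compound 2

The compounds below may be only part of what the source reports. "The series", "measured", "known", "first", "only" and "open" are said of these compounds alone.

- compound 1 `CC(C)c1ccc(OC(C)(Cc2ccccc2)C(=O)O)cc1` gives > 10 mg/kg (a limit of the assay)
- compound 2 `CCCc1ccc(CC(C)(Oc2ccc(C(C)C)cc2)C(=O)O)cc1` gives 0.5 mg/kg
- compound 3 `CCCCc1ccc(CC(C)(Oc2ccc(C(C)C)cc2)C(=O)O)cc1` gives 1 mg/kg

In a functional assay on the whole organism for inhibition, with Rattus norvegicus as the target (a higher number here means that more compound is needed for the effect, a lower number that less compound is needed), compound 2 lies within the scatter of compound 3, as shown by a 2.0-fold higher number from compound 2 to compound 3 (0.30 log units; within the scatter). Both stand well clear of the limit reached by compound 1, with an at least 20-fold lower number from compound 1 to compound 2 (1.30 log units; beyond the scatter) and an at least 10-fold lower number from compound 1 to compound 3 (1.00 log units; beyond the scatter).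

Compound 4 `CCCc1ccc(CC(C)(Oc2ccc(C(C)C)cc2)C(=O)NS(=O)(=O)C(F)(F)F)cc1` carries ((trifluoromethyl)sulfonyl)amino in place of hydroxy on a carbonyl carbon. Going by the values given here, none of the measured steps touches that carbonyl carbon, so they offer no direct size for this change, and no step beyond the scatter is expected. The estimated step is a 2.0-fold higher number from compound 2 to compound 4 (0.30 log units; within the scatter). For compound 4 the expected value is 1 mg/kg, with an estimated range from 0.2 mg/kg to 5 mg/kg.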

Compound 4, dose for half-maximal effect: > 10 mg/kg
Compound 4: only a limit was reported (the forecaster's own chance of this, stated with the estimate: 15%); middle value at least 10-fold (1.00 log units) from the limit.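

In this assay, the only change shown at the carbonyl carbon, ((trifluoromethyl)sulfonyl)amino in place of hydroxy, gives an at least 20-fold higher number from compound 2 to compound 4 (1.30 log units; beyond the scatter). Compound 4 gives > 10 mg/kg, which is a limit of the assay, so the step has a lower bound but no known end. Unlike the chain changes on the aromatic carbon, this swap shows that the carboxy group of compound 2 cannot be exchanged freely, and the reading stops at a shared ceiling: the limit of > 10 mg/kg in this assay, at which 2 of the 4 values shown sit.

From the compounds shown here alone, whether a tetrazole in place of the carboxy group would keep the number of compound 2 remains open. So does whether methylsulfonylamino in place of hydroxy would behave like the trifluoromethyl version.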